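Swapping the pyridyl substituents on a tamoxifen-like scaffold

A few compounds are considered here, and "the series" means these few. Any claim that something is new, unique, unknown or untested is made for them only; others in the source may bear on it.

Compound 2 `Cc1cccnc1/C(=C(\c1ccc(/C=C/C(=O)O)cc1)c1ccc2[nH]nc(F)c2c1)C1CCC1` holds the highest of the two numbers reported in a functional assay on MCF7 cells (Homo sapiens) for cytotoxicity, read by CellTiter-Glo, with a stated time of 5 days (on this read-out lower numbers stand for stronger inhibition and higher numbers for weaker inhibition), where compound 2 gives 4.2 nM. Its nearest neighbour is compound 1 `CS(=O)(=O)c1ccc(/C(=C(\c2ccc(/C=C/C(=O)O)cc2)c2ccc3[nH]nc(F)c3c2)C2CCC2)c(Cl)c1`, which in this assay gives 2.3 nM; the step of a 1.8-fold higher number from compound 1 to compound 2 (0.26 log units; within the scatter) and so does not separate the two.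

Compound 3 `N#Cc1cc(Cl)cnc1/C(=C(\c1ccc(/C=C/C(=O)O)cc1)c1ccc2[nH]nc(F)c2c1)C1CCC1` has not yet been measured. It differs from compound 2 in one place: 5-chloro-3-cyanopyridin-2-yl in place of 3-methylpyridin-2-yl on a double-bonded chain carbon bound to a double-bonded chain carbon and a saturated ring carbon. Among the compounds with values here, the only measured step that touches this position is the exchange of 2-chloro-4-(methylsulfonyl)phenyl for 3-methylpyridin-2-yl, which moved the number by a 1.8-fold higher number from compound 1 to compound 2 (0.26 log units; within the scatter), within the scatter. Within the data shown here, that one step is the sole guide, and it shows the position tolerating a sizeable change of aryl group without a shift beyond the scatter. On that basis compound 3 is expected to stay close to compound 2 in this assay, with an expected step of a 1.1-fold higher number from compound 2 to compound 3 (0.03 log units; within the scatter) that need not exceed the scatter. The estimate for compound 3 in this assay is 4.5 nM, with a range from 1.5 nM to 14 nM.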

Compound 3, half-maximal inhibitory concentration: 1.1 nM
The estimate for compound 3 lay 4.1-fold (0.61 log units) above the measured number; the whole stated range lies above it.
By their numbers in this assay, from the lowest: compound 3; then compounds 1 and 2 (each within the scatter of the next).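

In this assay, the place on a double-bonded chain carbon bound to a double-bonded chain carbon and a saturated ring carbon now shows a step beyond the scatter, which the exchange between compound 1 and compound 2 had not. Putting 5-chloro-3-cyanopyridin-2-yl in place of 3-methylpyridin-2-yl gives a 3.8-fold lower number from compound 2 to compound 3 (0.58 log units; beyond the scatter), and putting it in place of 2-chloro-4-(methylsulfonyl)phenyl gives a 2.1-fold lower number from compound 1 to compound 3 (0.32 log units; beyond the scatter), so both steps are modest but compound 3 holds the lowest number of the three, and the choice of aryl group at this place does register in the read-out. Nothing available explains why this group lowers the number.

The change brings in a chlorine and a nitrile and removes a methyl all at once, so the compounds shown cannot tell whether the chlorine, the nitrile or the loss of the methyl carries the step. Within the data shown here, they also leave open how a pyridine bearing only one of these groups would read, and whether a methoxy, an amine or a trifluoromethyl on the same ring would lower the number further or raise it.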